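Swapping a Dichlorophenyl for Cyclopropyl on the Sulfur Chain

A few compounds are considered here, and "the series" means these few. Any claim that something is new, unique, unknown or untested is made for them only; others in the source may bear on it.

Two compounds have been measured in a functional assay on MGC-803 cells (Homo sapiens) for inhibition, read by MTT assay, with a stated time of 72 h; on this read-out lower numbers stand for stronger inhibition and higher numbers for weaker inhibition:
Compound 1, `Cc1cc(Nc2cc(-c3ccccc3)[nH]n2)n2nc(SCc3c(Cl)cccc3Cl)nc2n1`, gives 5280 nM.
Compound 2, `Cc1cc(Nc2cc(-c3cccs3)[nH]n2)n2nc(SCc3ccc(Br)cc3)nc2n1`, gives 3770 nM.

Of these two numbers, compound 1 has the higher one, but its nearest neighbour, compound 2, sits within the usual scatter of the measurement, so the two cannot be ranked against each other. Among the measured compounds shown here, no pair of measured compounds differs in just one place, so there is no measured guide for the change considered here.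

Compound 3, `Cc1cc(Nc2cc(-c3ccccc3)[nH]n2)n2nc(SCC3CC3)nc2n1`, has not yet been measured. It differs from compound 1 in one place: cyclopropyl in place of 2,6-dichlorophenyl on a saturated chain carbon bound to a sulfur. The group that leaves is an aromatic six-membered ring carrying two chlorines; the group that enters is a small three-membered saturated ring. Nothing in the measured pair shows how this assay responds to such a swap, so the expectation rests on the size of the structural change alone. A step beyond the scatter, towards a higher number and so weaker inhibition, is expected: the estimated step is a 1.7-fold higher number from compound 1 to compound 3 (0.23 log units; within the scatter). Compound 3 is therefore estimated at 9000 nM, with a range from 3000 nM to 27000 nM.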

Compound 3, half-maximal inhibitory concentration: 16100 nM
Estimate against measurement, compound 3: 1.8-fold (0.25 log units) below; the measured number falls inside the stated range.
By their numbers in this assay, from the lowest: compounds 2 and 1 (each within the scatter of the next); then compound 3.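

In this assay, among the compounds shown here, the group on the saturated chain carbon bound to a sulfur proves to matter: cyclopropyl in place of 2,6-dichlorophenyl gives a 3.0-fold higher number from compound 1 to compound 3 (0.48 log units; beyond the scatter), a step beyond the scatter and the first single-place comparison in this set, since the two earlier compounds differ in more than one place. This change replaces an aromatic six-membered ring carrying two chlorines and 8 heavy atoms with a non-aromatic three-membered ring of 3 heavy atoms, while neither group has hydrogen-bond donors, hydrogen-bond acceptors or a net charge. No measured evidence here explains the step.

The single swap alters the ring type, the ring size and the chlorines together, so the compounds shown leave open which of these changes accounts for the step. From the compounds shown here alone, a cyclohexyl ring at this place would keep a six-membered ring without aromaticity or chlorines, while an unsubstituted phenyl ring would keep the aromatic ring without the chlorines, and how either would read in this assay remains unknown.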